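Swapping a Ring Hydrogen for Chlorine: Expected Cytotoxicity

A few compounds are considered here, and "the series" means these few. Any claim that something is new, unique, unknown or untested is made for them only; others in the source may bear on it.

The compounds here share a single core and were compared in an ADME assay on HEK-293T cells (Homo sapiens) for cytotoxicity, read by MTT assay, with a stated time of 24 h; on this read-out lower numbers stand for higher toxicity in this test and higher numbers for lower toxicity in this test. Compound 2 `O=C(c1ccccc1)n1c(-c2cn(-c3ccccc3)nc2-c2ccc(F)cc2)nc2ccccc21` gives 180000 nM in this assay. For the measured compounds named here, its only measured neighbour, compound 1 `Cc1ccccc1C(=O)n1c(-c2cn(-c3ccccc3)nc2-c2ccc(F)cc2)nc2ccccc21`, gives 189000 nM. The step between them, a 1.1-fold lower number from compound 1 to compound 2 (0.02 log units; within the scatter), replaces a methyl on an aromatic carbon of the benzoyl ring with hydrogen and leaves the read-out essentially unchanged. Going by the values given here, of the two numbers known, compound 2 holds the lower one, but the gap to compound 1 lies within the scatter, so the two compounds cannot be told apart on this read-out.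

Compound 3 `O=C(c1ccc(Cl)cc1)n1c(-c2cn(-c3ccccc3)nc2-c2ccc(F)cc2)nc2ccccc21` differs from compound 2 by chloro in place of hydrogen on an aromatic carbon. Among the compounds with values here, no measured step introduces a chloro group, so the only guidance is the step from compound 1 to compound 2, which changed a substituent on the same benzoyl ring and stayed within the scatter. On that basis compound 3 is expected to move by a 1.1-fold lower number from compound 2 to compound 3 (0.02 log units; within the scatter), that is, no step beyond the scatter. The estimate for compound 3 is therefore 170000 nM, with a range from 85000 nM to 340000 nM.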

Compound 3, half-maximal cytotoxic concentration: 179000 nM
Beside the measured number, compound 3's estimate is 1.1-fold (0.02 log units) below it, and the stated range covers the measured number.
By their numbers in this assay, from the lowest: compounds 3, 2 and 1 (each within the scatter of the next).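

For the compounds shown here, the earlier pair spoke only to a methyl group on the benzoyl ring, whereas compound 3 gives the first reading for a chloro group, here on an aromatic carbon para to a large group, and in this assay this change is a 1.0-fold lower number from compound 2 to compound 3 (0.00 log units; within the scatter) with no step beyond the usual scatter. The larger swap, 4-chlorophenyl in place of 2-methylphenyl on the carbonyl carbon, is a 1.1-fold lower number from compound 1 to compound 3 (0.02 log units; within the scatter) and so also leaves the two compounds indistinguishable on this read-out. The three compounds, with hydrogen, methyl or chloro on this ring, therefore cannot be told apart here, and no measurement is available to explain this result.

As far as these compounds go, whether a different kind of group on this ring, such as an amine, a carboxylic acid or a longer alkyl chain, would separate from these three compounds remains open. Also open, from the compounds shown here alone, is whether a chloro group would read the same way on another ring of the shared core.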